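Bromo for Chloro on a Second Imidazolidinone Core

The compounds below may be only part of what the source reports. "The series", "measured", "known", "first", "only" and "open" are said of these compounds alone.

Three analogues of one sulfonate series have been tested in a functional assay on HT-29 cells (Homo sapiens) for antiproliferative activity, read by sulforhodamine B assay, with a stated time of 48 h; a higher number here means a weaker inhibitor, a lower number a stronger inhibitor. Compound 1 `CN1CCN(c2ccc(S(=O)(=O)Oc3cccc(Cl)c3)cc2)C1=O` gives 2100 nM, compound 2 `CN1CCN(c2ccc(S(=O)(=O)Oc3cccc(Br)c3)cc2)C1=O` gives 1300 nM, and compound 3 `CCN1CCN(c2ccc(S(=O)(=O)Oc3cccc(Cl)c3)cc2)C1=O` gives 6800 nM. The change from compound 1 to compound 2 is bromo in place of chloro on an aromatic carbon, and it made a 1.6-fold lower number from compound 1 to compound 2 (0.21 log units; within the scatter). Compound 3 differs from compound 1 by methyl in place of hydrogen on a saturated chain carbon bound to an amide-type nitrogen in a ring, a step of a 3.2-fold higher number from compound 1 to compound 3 (0.51 log units; beyond the scatter). Compound 4 `CCN1CCN(c2ccc(S(=O)(=O)Oc3cccc(Br)c3)cc2)C1=O` has not yet been measured; it differs from compound 3 by bromo in place of chloro on an aromatic carbon, the same change already seen from compound 1 to compound 2. Because the earlier step was a 1.6-fold lower number from compound 1 to compound 2 (0.21 log units; within the scatter), compound 4 is expected to sit close to compound 3, with an estimated step of a 1.5-fold lower number from compound 3 to compound 4 (0.18 log units; within the scatter). The estimate for compound 4 in this assay is 4500 nM, expected between 2000 nM and 10000 nM.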

Compound 4, half-maximal inhibitory concentration: 3800 nM
Beside the measured number, compound 4's estimate is 1.2-fold (0.07 log units) above it; low and high end bracket the measured number.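

In this assay, bromo in place of chloro gave a 1.8-fold lower number from compound 3 to compound 4 (0.25 log units; within the scatter) on the ethyl-bearing core, matching the step on the core of compound 1: the same change on two cores in this assay, a 1.6-fold lower number (0.21 log units; within the scatter) from compound 1 to compound 2 and a 1.8-fold lower number (0.25 log units; within the scatter) from compound 3 to compound 4, 1.1-fold (0.04 log units) apart, within the scatter of two such steps. Methyl in place of hydrogen on the chain gave a 2.9-fold higher number from compound 2 to compound 4 (0.47 log units; beyond the scatter) with bromo present, matching the step seen with chloro: the same change on two cores in this assay, a 3.2-fold higher number (0.51 log units; beyond the scatter) from compound 1 to compound 3 and a 2.9-fold higher number (0.47 log units; beyond the scatter) from compound 2 to compound 4, 1.1-fold (0.04 log units) apart, within the scatter of two such steps. Both changes therefore carried across this one pair of cores, yet each halogen step lies within the scatter, and the data show neither a real difference between bromo and chloro nor a rule for the wider series.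

Going by these compounds, whether this agreement holds for iodo or a nitrile in that place remains open. So does whether it holds for a chain longer than the one in compound 3.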